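This account rests on a few compounds, and the source may have more. Where it says the series, first, only, none or still open, it means among the compounds named here.

In an assay on CHO cells for binding affinity to Melanocortin receptor 4 (Homo sapiens) (on this read-out lower numbers stand for stronger inhibition and higher numbers for weaker inhibition), compound 1 `COc1ccc(-n2nc(Sc3ccc(Cl)cc3)cc(CC[C@@H](C)NC(=O)[C@H]3CCNC[C@@H]3c3ccc(F)cc3)c2=O)cc1` gives 66 nM. Compound 2 `COc1ccc(-n2nc(Sc3ccc(Cl)cc3)cc(CC[C@@H](C)NC(=O)[C@H]3CNC[C@@H]3c3ccccc3F)c2=O)cc1`, which in this assay gives 160 nM, stands as the higher of the two numbers, with its gap to compound 1 beyond the scatter of repeated measurements. Compound 3 `COc1ccc([C@H]2CNC[C@@H]2C(=O)N[C@H](C)CCc2cc(Sc3ccc(Cl)cc3)nn(-c3ccc(OC)cc3)c2=O)cc1` is not yet measured; it differs from compound 2 by 4-methoxyphenyl in place of 2-fluorophenyl on a saturated ring carbon. For the measured compounds named here, no measured pair shows this kind of change, so nothing in these data predicts its direction; a step roughly within the scatter is expected, a 1.3-fold higher number from compound 2 to compound 3 (0.10 log units; within the scatter). Compound 3 is therefore estimated at 200 nM, with a range from 60 nM to 700 nM.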

Compound 3, half-maximal inhibitory concentration: 19 nM
Compound 3: the middle estimate sits 11-fold (1.02 log units) above what was measured; the whole stated range lies above it.
By their numbers in this assay, from the lowest: compound 3; then compound 1; then compound 2.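

In this assay, 4-methoxyphenyl in place of 2-fluorophenyl on this saturated ring carbon gives an 8.4-fold lower number from compound 2 to compound 3 (0.93 log units; beyond the scatter) and so moves the number well beyond the scatter. For the compounds shown here, this is the first pair to show that the aryl group at this place, two ring bonds from the ring nitrogen, affects the read-out. Nothing available explains the size of this step. The compounds shown leave open whether the lower number follows the arrival of the methoxy group or the loss of fluorine. They also leave open how an unsubstituted phenyl group on this carbon would compare.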